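Swapping an aryl nitrile for a branched alkyl group

The compounds below may be only part of what the source reports. "The series", "measured", "known", "first", "only" and "open" are said of these compounds alone.

Measured so far in an in vitro functional assay on cells for agonist activity at Bombesin receptor subtype-3 (Homo sapiens), read by luminescence and calcium flux; on this read-out lower numbers stand for an effect already at smaller amounts and higher numbers for an effect only at larger amounts of compound:
Compound 1 `CCCCc1cnc(C(CCCO)Cc2ccc(-c3ccccc3C(=O)O)cc2)[nH]1` gives 1900 nM.
Compound 2 `CCCCc1cnc(C(CCCC)Cc2ccc(-c3ccccc3C(=O)O)cc2)[nH]1` gives 2660 nM.
Compound 3 `N#Cc1cccc(Cc2cnc(CCc3ccc(-c4ccccc4C(=O)O)cc3)[nH]2)c1` gives 812 nM.

Compound 3 stands lowest of the three numbers, and its gaps to both compound 1 and compound 2 are beyond the scatter, so among these three it is the most potent in this assay. Compound 4 `CCC(C)(CC)Cc1cnc(CCc2ccc(-c3ccccc3C(=O)O)cc2)[nH]1` keeps the shared core of compound 3 and differs from it in one place: 1-ethyl-1-methylpropyl in place of 3-cyanophenyl on a saturated chain carbon bound to an aromatic carbon.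

Among the measured compounds shown here, only one measured step is on hand for comparison, and it is a loose one. Between compound 1 and compound 2 a hydroxy on a chain is exchanged for a methyl, and that gave a 1.4-fold higher number from compound 1 to compound 2 (0.15 log units; within the scatter). That step shows an exchange of a polar for a nonpolar group in a side chain leaving this assay about unchanged. For the measured compounds named here, the change here is larger, removing an aromatic ring with its nitrile and putting a branched saturated chain in its place, so no measured step speaks to it directly. Given that compound 3 is the strongest point and the new group has little in common with what it replaces, a step toward a higher number is expected, a 2.5-fold higher number from compound 3 to compound 4 (0.39 log units; beyond the scatter). Compound 4 is therefore estimated at 2000 nM, within 600 nM to 6500 nM.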

Compound 4, half-maximal effective concentration: 76 nM
For compound 4 the middle estimate is 26-fold (1.42 log units) above the measured one, outside the stated range (below it).
By their numbers in this assay, from the lowest: compound 4; then compound 3; then compounds 1 and 2 (each within the scatter of the next).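

Exchanging 3-cyanophenyl for 1-ethyl-1-methylpropyl gave an 11-fold lower number from compound 3 to compound 4 (1.03 log units; beyond the scatter) in this assay, so a low number at this place, on a saturated chain carbon bound to an aromatic carbon, requires neither an aromatic ring nor a nitrile. The group that enters has no ring and no hydrogen-bond acceptor, and with 6 heavy atoms against 8 it is also the smaller of the two by that count, which shows that a large drop in the number does not depend on adding atoms here. Nothing available explains why the number fell this far, and no supporting measurement bears on the result.

The compounds shown contain only one saturated group at this place, so it remains open whether the branching itself matters or whether any saturated group would do, a question that a straight pentyl chain or a cyclohexyl ring could help to settle. From the compounds shown here alone, it also remains open how a plain phenyl group without the nitrile, or a chain ending in an amine, would compare with compound 3 and compound 4.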